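A Fluoro Step from Compound 2 to Compound 3

A few compounds are considered here, and "the series" means these few. Any claim that something is new, unique, unknown or untested is made for them only; others in the source may bear on it.

Compound 1 `Clc1ccc(Cn2c(-c3c[nH]c4cc(Cl)ccc34)c(-c3ccccc3)c3ccccc32)cc1` gives 7.61
Compound 2 `O=C(O)c1[nH]c2cc(Cl)ccc2c1-c1c(-c2ccccc2)c2ccccc2n1Cc1ccc(Cl)cc1` gives 7.22

Both numbers come from a physicochemical assay for lipophilicity (on this read-out lower numbers stand for lower lipophilicity and higher numbers for higher lipophilicity), and they are the only ones available so far. Compound 2 holds the lower position, with 7.22 against the higher number of compound 1. The next compound to be measured is compound 3 `O=C(O)c1[nH]c2cc(Cl)ccc2c1-c1c(-c2ccc(F)cc2)c2ccccc2n1Cc1ccc(Cl)cc1` and it has one change from compound 2, fluoro in place of hydrogen on an aromatic carbon so that phenyl becomes 4-fluorophenyl.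

Going by the values given here, only one measured step is available as a guide. It is a number 0.39 log units lower from compound 1 to compound 2 (beyond the scatter) and it is modest, but it concerns carboxy in place of hydrogen on an aromatic carbon, a different group. Among the compounds with values here, no measured pair shows what fluoro does here, so this guide is weak and the forecast stays cautious. A small rise is expected, with an estimated size of a number 0.13 log units higher from compound 2 to compound 3 (within the scatter) and so probably none beyond the scatter. In this assay compound 3 is estimated at 7.35 with an expected range from 7.05 to 7.65 for its measured value.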

Compound 3, partition coefficient: 7.38
The estimate for compound 3 lay 0.03 log units below the measured number; the range from low to high includes it.
By their numbers in this assay, from the lowest: compounds 2, 3 and 1 (each within the scatter of the next, the first and the last beyond it).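

At this position, on a six-membered aromatic ring of carbon only and para to a large group, fluoro in place of hydrogen turns phenyl into 4-fluorophenyl, and this assay records a number 0.16 log units higher from compound 2 to compound 3 (within the scatter) for that single change. Going by these compounds alone, this is the first measured fluoro step, and unlike the earlier carboxy step it cannot be told apart from the ordinary spread of repeated measurements, so no real shift can be claimed in either direction for this swap at this place. No measurement at hand speaks to what lies behind this step.

A single fluoro at a single position cannot show whether a larger group on the same ring carbon, such as chloro, methoxy or an amine, would give a step beyond the scatter. On these data alone, it also remains open whether fluoro elsewhere on the phenyl ring or on the shared core would read the same way, and whether this swap would give a similar step in a compound without the carboxylic acid of compound 2.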